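This account rests on a few compounds, and the source may have more. Where it says the series, first, only, none or still open, it means among the compounds named here.

Compound 3 `CCOC(=O)c1cnc(-c2cc3ccccc3s2)nc1NN1C(=O)C=C(C)C1=O` gives 4000 nM in a functional assay on Jurkat cells for inhibition of nuclear factor NF-kappa-B complex (Homo sapiens) (on this read-out lower numbers stand for stronger inhibition and higher numbers for weaker inhibition), the highest number of the three measured compounds. Compound 1 `CCOC(=O)c1cnc(SC)nc1NN1C(=O)C=C(C)C1=O` gives 200 nM, and compound 2 `CCOC(=O)c1cnc(-c2ccc(C)s2)nc1NN1C(=O)C=C(C)C1=O` gives 200 nM. Compound 4 `CCOC(=O)c1cnc(C(=O)c2ccco2)nc1NN1C(=O)C=C(C)C1=O` is not yet measured and differs from compound 3 in one place: (furan-2-yl)carbonyl in place of 1-benzothiophen-2-yl on an aromatic carbon. The steps of a 20-fold higher number from compound 1 to compound 3 (1.30 log units; beyond the scatter) and a 20-fold higher number from compound 2 to compound 3 (1.30 log units; beyond the scatter) bear on this change, as both of them added the very group that now leaves. Taking that group away is expected to bring the number back down, although no measured compound carries the entering group, so the size is uncertain. The expected step is an 8.0-fold lower number from compound 3 to compound 4 (0.90 log units; beyond the scatter). Compound 4 is expected to give about 500 nM, within 100 nM to 3000 nM.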

Compound 4, half-maximal inhibitory concentration: 700 nM
For compound 4 the middle estimate is 1.4-fold (0.15 log units) below the measured one, and the stated range covers the measured number.
By their numbers in this assay, from the lowest: compounds 1 and 2 (each within the scatter of the next); then compound 4; then compound 3.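

At this position, between two ring nitrogen atoms, a group other than the 1-benzothiophen-2-yl brings the number in this assay back down (a 5.7-fold lower number from compound 3 to compound 4 (0.76 log units; beyond the scatter)). The recovery is only partial: (furan-2-yl)carbonyl still reads weaker than 5-methylthiophen-2-yl (a 3.5-fold higher number from compound 2 to compound 4 (0.54 log units; beyond the scatter)) and methylsulfanyl (a 3.5-fold higher number from compound 1 to compound 4 (0.54 log units; beyond the scatter)). No available measurement explains these differences.

From the compounds shown here alone, it remains open whether the furan ring or the carbonyl drives the change. Going by these compounds, how a plain furan-2-yl or an amine would compare at this position is also open.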